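Swapping the Aryl Ring at the Chain End of Compound 1

The source may hold more compounds than are shown below. What is called first, only, known or untested is meant among the compounds shown, and "the series" means these compounds.

Compound 1 `COc1ccc(/C=C/C(=O)c2cc3ccc(OCc4cccc(OC)c4)cc3oc2=O)cc1` is one of three compounds tested in a functional assay on MCF7 cells (Homo sapiens) for cytotoxicity, read by MTT assay, with a stated time of 72 h; a lower number here means a stronger inhibitor, a higher number a weaker inhibitor. In this assay compound 1 gives > 100000 nM, and this is a limit of the assay rather than a number. Compound 1 thus sits at the limit of > 100000 nM in this assay, at which 1 of the 3 values shown sits, so all that is known is that it is a weak inhibitor. The other two compounds share the core but carry a different aryl group at the end of the chain and a different group on the core oxygen. Compound 2 `COc1cccc(/C=C/C(=O)c2cc3cc(O)ccc3oc2=O)c1OC` gives 8800 nM in this assay. Compound 3 `COc1cccc(/C=C/C(=O)c2cc3cc(OCc4ccccc4)ccc3oc2=O)c1OC` gives 21300 nM. Going by the values given here, the only step between two compounds that differ in one place is a 2.4-fold higher number from compound 2 to compound 3 (0.38 log units; beyond the scatter).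

Compound 4 `COc1cccc(COc2ccc3cc(C(=O)/C=C/c4c(Cl)cccc4Cl)c(=O)oc3c2)c1` has not yet been measured. It differs from compound 1 by 2,6-dichlorophenyl in place of 4-methoxyphenyl on a double-bonded chain carbon bound to a double-bonded chain carbon. Among the compounds with values here, no measured step bears on this change: the single measured step concerns a benzyl group on an oxygen of the core, not the aryl group at the chain end. With no guide, compound 4 is expected to stay close to where compound 1 stands, and may again come back only as a limit. The estimate for compound 4 is 100000 nM, with a range from 25000 nM to 400000 nM. This corresponds to an expected step of a number no higher from compound 1 to compound 4 (the limit leaves the size open), which is expected not to go beyond the scatter.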

Compound 4, half-maximal inhibitory concentration: 10100 nM
The estimate for compound 4 lay 9.9-fold (1.00 log units) above the measured number; the measured number lies below the stated range.
By their numbers in this assay, from the lowest: compounds 2 and 4 (each within the scatter of the next); then compound 3. At a limit, above all of these: compound 1.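

In this assay, the aryl group at the chain end proves able to move the result: 2,6-dichlorophenyl in place of 4-methoxyphenyl gives an at least 9.9-fold lower number from compound 1 to compound 4 (0.99 log units; beyond the scatter). Going by these compounds alone, the earlier compounds offered only one comparison, a change on the core oxygen, so this is the first measured step for a change on a double-bonded chain carbon bound to a double-bonded chain carbon, and it lies beyond the scatter with the rest of compound 1 left as it was. The true size of the step stays unknown, because the value of compound 1 is a limit of the assay and not a number: the limit of > 100000 nM in this assay, at which 1 of the 4 values shown sits.

The swap replaces a whole aryl group, so the compounds shown cannot tell whether the gain comes from losing the methoxy group, from gaining the two chlorine atoms, or from both together. Going by these compounds, it also remains open how a plain phenyl ring, or a phenyl ring carrying an amine, would read at this place on the chain, and whether the same swap would give a similar step with a different group on the core oxygen.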